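Two chlorines for one bromine on the amide aryl

The source may report more compounds than this note shows. Statements on the series, on what has been measured and on what is new or still open speak of the compounds shown alone.

Of the compounds shown here, three sharing one core have been tested in a functional assay on MDA-MB-231 cells (Homo sapiens) for inhibition, read by MTT assay, with a stated time of 72 h; on this read-out higher numbers stand for weaker inhibition and lower numbers for stronger inhibition. Compound 1 `O=C(CSc1nc(Nc2ccccc2)c2ccccc2n1)Nc1ccccc1Br` gives 14100 nM, the highest of the two numbers actually read. Compound 3 `O=C(CSc1nc(Nc2ccccc2)c2ccccc2n1)Nc1ccc(Br)cc1` gives 11500 nM, and a 1.2-fold lower number from compound 1 to compound 3 (0.09 log units; within the scatter) shows that 4-bromophenyl in place of 2-bromophenyl on the amide-type nitrogen changes little. Compound 2 `O=C(CSc1nc(Nc2ccccc2)c2ccccc2n1)Nc1cccc(F)c1` reached only the assay limit of > 50000 nM, so that an at least 3.5-fold higher number from compound 1 to compound 2 (0.54 log units; beyond the scatter) and an at least 4.3-fold lower number from compound 2 to compound 3 (0.63 log units; beyond the scatter) are bounds rather than numbers; the fluorine bearing compound thus sits at the limit of > 50000 nM in this assay, at which 1 of the 3 values shown sits.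

Compound 4 `O=C(CSc1nc(Nc2ccccc2)c2ccccc2n1)Nc1ccc(Cl)cc1Cl` differs from compound 1 by 2,4-dichlorophenyl in place of 2-bromophenyl on an amide-type nitrogen. The new group keeps a halogen on the same side of the ring as in compound 1 and adds one where compound 3 carries its bromine, and that addition in compound 3 stayed within scatter. Only compound 2 warns of a weaker result, and it carries a different substitution. In this assay compound 4 is therefore expected to give 10000 nM, in the range 4000 nM to 30000 nM. The expected step is a 1.4-fold lower number from compound 1 to compound 4 (0.15 log units; within the scatter), which is estimated to remain within the scatter.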

Compound 4, half-maximal inhibitory concentration: 19400 nM
Beside the measured number, compound 4's estimate is 1.9-fold (0.29 log units) below it; low and high end bracket the measured number.
By their numbers in this assay, from the lowest: compounds 3, 1 and 4 (each within the scatter of the next). At a limit, above all of these: compound 2.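

With 2,4-dichlorophenyl on the amide-type nitrogen, the data show a 1.4-fold higher number from compound 1 to compound 4 (0.14 log units; within the scatter) and a 1.7-fold higher number from compound 3 to compound 4 (0.23 log units; within the scatter), so two chlorines in place of one bromine leave the number within the scatter of both bromine compounds, with no gain from the second halogen. The remaining step, an at least 2.5-fold lower number from compound 2 to compound 4 (0.41 log units; beyond the scatter), is a bound rather than a measured difference, yet it sets compound 4 with compound 1 and compound 3, while compound 2 goes against any rule that halogens on this ring are interchangeable. Compound 2 remains the only compound at a limit: the limit of > 50000 nM in this assay, at which 1 of the 4 values shown sits.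

Still open, on these data alone, is whether 3-fluorophenyl falls away for its fluorine or for where that fluorine sits, which 3-bromophenyl or 4-fluorophenyl would separate. Also open, as far as these compounds go, is how a non-halogen group on this ring, such as methoxy or an amine, would read.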